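From methyl to methoxy on the way to compound 4

This account rests on a few compounds, and the source may have more. Where it says the series, first, only, none or still open, it means among the compounds named here.

compound 1 `COc1ccc(-c2c(C(=O)c3cc(OC)c(OC)c(OC)c3)sc3ccccc23)cc1` gives 1700 nM
compound 2 `COc1cc(C(=O)c2sc3ccccc3c2Nc2ccc(Cl)cc2)cc(OC)c1OC` gives 1100 nM
compound 3 `COc1cc(C(=O)c2sc3ccccc3c2Nc2ccc(C)cc2)cc(OC)c1OC` gives 1600 nM

All three were read in a functional assay on K562 cells (Homo sapiens) for antiproliferative activity, read by MTT assay, with a stated time of 72 h (on this read-out lower numbers stand for stronger inhibition and higher numbers for weaker inhibition), and cannot be separated there. Compound 3 sits within the scatter of both compound 1 and compound 2, so it holds no distinct place among them. Still unmeasured is compound 4 `COc1ccc(Nc2c(C(=O)c3cc(OC)c(OC)c(OC)c3)sc3ccccc23)cc1`, which differs from compound 3 by methoxy in place of methyl on an aromatic carbon, para to a large group.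

The nearest evidence is the exchange at that same place, a 1.5-fold higher number from compound 2 to compound 3 (0.16 log units; within the scatter). Two further steps change the link to the core, a 1.1-fold lower number from compound 1 to compound 3 (0.03 log units; within the scatter) and a 1.5-fold lower number from compound 1 to compound 2 (0.19 log units; within the scatter). Among the compounds with values here, none of these steps leaves the scatter, although no measured step tests methoxy at this place directly. A change beyond the scatter is therefore not expected in this assay, in either direction. The expected step is a 1.1-fold lower number from compound 3 to compound 4 (0.06 log units; within the scatter). For compound 4 the estimated value is 1400 nM, with an expected range from 700 nM to 2800 nM.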

Compound 4, half-maximal inhibitory concentration: 2900 nM
Estimate against measurement, compound 4: 2.1-fold (0.32 log units) below; the whole stated range lies below it.
By their numbers in this assay, from the lowest: compounds 2, 3, 1 and 4 (each within the scatter of the next, the first and the last beyond it).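

At this place, on an aromatic carbon para to a large group, this assay now gives a first separation beyond the scatter, though a modest one, with a 2.6-fold higher number from compound 2 to compound 4 (0.42 log units; beyond the scatter) as methoxy replaces chloro, while the exchange of methyl for methoxy stays within the scatter, with a 1.8-fold higher number from compound 3 to compound 4 (0.26 log units; within the scatter). Adding the amino link while keeping the methoxy also stays within the scatter, with a 1.7-fold higher number from compound 1 to compound 4 (0.23 log units; within the scatter), so the two links are not told apart here. No measurement shown here accounts for the gap between chloro and methoxy.

The compounds shown leave open how an amine, a hydroxyl or a carboxylic acid would read at this place. They also leave open whether a longer chain such as ethoxy would stay within the scatter of methoxy.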